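Chloro to methyl beside the ring nitrogen: an expected shift

The source may report more compounds than this note shows. Statements on the series, on what has been measured and on what is new or still open speak of the compounds shown alone.

Measured compounds:
compound 1 `CCCc1cncc(OC[C@@H]2CCN2)c1`: 0.039 nM
compound 2 `Clc1ncccc1OC[C@@H]1CCN1`: 2.3 nM

The series is followed in an assay on brain for binding affinity to Neuronal acetylcholine receptor; alpha4/beta2 (Rattus norvegicus), read by radioligand binding (a higher number here means a weaker inhibitor, a lower number a stronger inhibitor), in which compound 1 gives 0.039 nM and compound 2 gives 2.3 nM. Within the data shown here, of the two numbers known, compound 2 shows the higher one, so compound 2 is the weaker binder of the pair; the gap to compound 1 is well beyond the usual scatter. Among the measured compounds shown here, no single-point step between two measured compounds is known here, so there is no measured precedent for the change that leads to compound 3.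

Compound 3 `Cc1ncccc1OC[C@@H]1CCN1` differs from compound 2 in one place: methyl in place of chloro on an aromatic carbon. The change swaps one single heavy atom for another on the aromatic carbon next to the ring nitrogen, leaving the rest of the molecule untouched. Without a comparable measured pair, the step is expected to be small and in the direction of a weaker binder, close to the edge of the scatter, so that from compound 2 to compound 3 a change of a 2.0-fold higher number from compound 2 to compound 3 (0.29 log units; within the scatter) is estimated. Compound 3 is therefore expected to give about 4.5 nM in this assay, with a plausible range from 1.2 nM to 17 nM.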

Compound 3, inhibition constant: 1.36 nM
Compound 3: middle estimate off by 3.3-fold (0.52 log units), on the high side, and the stated range covers the measured number.
By their numbers in this assay, from the lowest: compound 1; then compounds 3 and 2 (each within the scatter of the next).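

In this assay, among these compounds, methyl in place of chloro on the aromatic carbon next to the ring nitrogen gives a 1.7-fold lower number from compound 2 to compound 3 (0.23 log units; within the scatter), and this is the first single-point step that can be read directly. It shows that, at this position, the two groups cannot be told apart in this measurement: each is a single heavy atom with no hydrogen-bond donors or acceptors, and swapping one for the other moves the number no further than repeat measurements would. No accompanying measurement bears on why the two groups give such similar results.

What the compounds leave open is whether this tolerance holds only for groups of one heavy atom, or whether an ethyl group, a methoxy group or an amine on the same carbon would also stay within the scatter of compound 2. Compound 1 differs from both compound 2 and compound 3 in more than one place, so it gives no separate reading of this position, and whether the two groups would remain equivalent on a changed core is also unanswered.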